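Trimethoxyphenyl versus hydroxy-methoxyphenyl on the enone arm

A few compounds are considered here, and "the series" means these few. Any claim that something is new, unique, unknown or untested is made for them only; others in the source may bear on it.

Measured so far:
compound 1 `COc1cc(/C=C/C(=O)c2cccc(-n3cc(-c4ccccc4)[nH]c3=O)c2)cc(OC)c1OC`: 330 nM
compound 2 `COc1ccc(-c2cn(-c3cccc(C(=O)/C=C/c4ccc(O)c(OC)c4)c3)c(=O)[nH]2)cc1`: 1930 nM

In a functional assay on HCT-116 cells (Homo sapiens) for inhibition (a higher number here means a weaker inhibitor of growth, a lower number a stronger inhibitor of growth), compound 2 gives 1930 nM, the highest of the two numbers; compound 1 gives 330 nM, a gap beyond the scatter. Compound 3 `COc1ccc(-c2cn(-c3cccc(C(=O)/C=C/c4cc(OC)c(OC)c(OC)c4)c3)c(=O)[nH]2)cc1` differs from compound 2 by 3,4,5-trimethoxyphenyl in place of 4-hydroxy-3-methoxyphenyl on a double-bonded chain carbon bound to a double-bonded chain carbon. For the measured compounds named here, no one-point step between measured compounds is available. Still, compound 1 carries the same 3,4,5-trimethoxyphenyl on the chain and gives 330 nM, so a drop in the number beyond the scatter is expected, estimated as a 4.3-fold lower number from compound 2 to compound 3 (0.63 log units; beyond the scatter). Compound 3 is expected near 450 nM, within 150 nM to 1500 nM.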

Compound 3, concentration for 50% growth inhibition: 370 nM
Beside the measured number, compound 3's estimate is 1.2-fold (0.09 log units) above it; the range from low to high includes it.
By their numbers in this assay, from the lowest: compounds 1 and 3 (each within the scatter of the next); then compound 2.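

In this assay, for the compounds shown here, 3,4,5-trimethoxyphenyl in place of 4-hydroxy-3-methoxyphenyl on a double-bonded chain carbon bound to a double-bonded chain carbon gives a 5.2-fold lower number from compound 2 to compound 3 (0.72 log units; beyond the scatter) as the first one-point reading at this position. With 3,4,5-trimethoxyphenyl held on the chain, methoxy in place of hydrogen on an aromatic carbon gives a 1.1-fold higher number from compound 1 to compound 3 (0.05 log units; within the scatter) and so separates nothing on that side of the series. No evidence on the cause of the larger step is at hand.

The swap removes a hydroxy and changes the methoxy count together, so the shown compounds do not tell which of these carries the step. A 3,4-dimethoxyphenyl on the chain would pull the two apart.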